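The compounds below may be only part of what the source reports. "The series", "measured", "known", "first", "only" and "open" are said of these compounds alone.

Working notes on the series.

Compound 1 `Cc1noc(-c2nc(C)c3c(c2N)C(=O)N(Cc2ccc(F)cc2)C3=O)n1` is anchored only by a limit in a physicochemical assay for solubility, using the shake flask method, in simulated intestinal fluid, measured as kinetic solubility, with a stated time of 2 h, at 25 degrees C, at pH 6.5; on this read-out lower numbers stand for lower solubility and higher numbers for higher solubility: compound 1 gives < 5000 nM, a limit rather than a number. Compound 2 `Cc1noc(-c2nc(C)c3c(c2N)C(=O)N(Cc2ccccc2F)C3=O)n1` also sits at a limit, giving < 5000 nM in this assay. Compound 3 `Cc1noc(-c2nc(C)c3c(c2N)C(=O)N(Cc2ccncc2)C3=O)n1` gives 26400 nM in this assay. Two of the three shown values sit at the limit of < 5000 nM in this assay, at which 2 of the 3 values shown sit, so the step that the two limits leave unreadable from compound 1 to compound 2 cannot be read, while an at least 5.2-fold higher number from compound 1 to compound 3 (0.72 log units; beyond the scatter) and an at least 5.2-fold higher number from compound 2 to compound 3 (0.72 log units; beyond the scatter) show the only readable movement.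

Compound 4 `Cc1noc(-c2nc(C)c3c(c2N)C(=O)N(Cc2ccc(N4CCCC4=O)cc2)C3=O)n1` differs from compound 1 by 2-oxopyrrolidin-1-yl in place of fluoro on an aromatic carbon. Within the data shown here, no measured step changes this position with a comparable group; only the step from compound 1 to compound 3 offers a direction. Compound 4 is therefore expected to move upward from the limit, estimated at 9000 nM (range 2500 nM to 35000 nM), an expected step of an at least 1.8-fold higher number from compound 1 to compound 4 (0.25 log units; that floor lies within the scatter).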

Compound 4, solubility: < 5000 nM
Compound 4 ended at the assay's limit (the forecaster's own chance of this, stated with the estimate: 40%); middle value at least 1.8-fold (0.25 log units) away from the limit.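

In this assay compound 4 gives < 5000 nM as a limit and not a number, so no new step can be read from compound 1 to compound 4: the limit of < 5000 nM in this assay, at which 3 of the 4 values shown sit.

On these data alone, what 2-oxopyrrolidin-1-yl in place of fluoro does to this read-out stays open, as do the actual numbers for compound 1, compound 2 and compound 4.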